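The source may hold more compounds than are shown below. What is called first, only, known or untested is meant among the compounds shown, and "the series" means these compounds.

Compound 1 `O=C(N1CCOCC1)n1cc(-c2ccc3cn[nH]c3c2)ccc1=O` was tested in an assay for inhibition of MAP kinase-interacting serine/threonine-protein kinase 2 (Homo sapiens), read by luminescence and ADP-Glo, with a stated time of 2 h (on this read-out lower numbers stand for stronger inhibition and higher numbers for weaker inhibition), where it gives only a limit, > 2000 nM. Among the compounds with values here, compound 2 `O=c1ccc(-c2ccc3cn[nH]c3c2)cn1Cc1ccccc1` gives 75 nM in this assay, and this is the only actual number among the two values shown. The remaining value is a limit (the limit of > 2000 nM in this assay, at which 1 of the 2 values shown sits). Within the data shown here, the one measured step, an at least 26-fold lower number from compound 1 to compound 2 (1.42 log units; beyond the scatter), is large. Compound 3 `Cn1cc(-c2ccc3cn[nH]c3c2)ccc1=O` differs from compound 2 by hydrogen in place of phenyl on a saturated chain carbon bound to an aromatic nitrogen. The step from compound 1 to compound 2 is the only one that bears on this change, and it exchanged the whole group on the aromatic nitrogen, so it speaks to compound 3 only in part; still, it shows that what sits on that nitrogen moves the number a great deal. Compound 3 is therefore expected to give a weaker number than compound 2, estimated at 600 nM, with a range of 150 nM to 3000 nM, meaning an expected step of an 8.0-fold higher number from compound 2 to compound 3 (0.90 log units; beyond the scatter).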

Compound 3, half-maximal inhibitory concentration: > 2000 nM
Compound 3: no number, only a limit (the forecaster's own chance of this, stated with the estimate: 20%); at least 3.3-fold (0.52 log units) between middle value and limit.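

In this assay, cutting benzyl back to methyl on the aromatic nitrogen gives an at least 26-fold higher number from compound 2 to compound 3 (1.42 log units; beyond the scatter). The earlier step exchanged the whole group on that nitrogen, whereas this one takes away the phenyl alone, so the number of compound 2 depends on that phenyl itself and is not kept by a methyl on the nitrogen. Compound 3 gives only a limit, so the step between compound 1 and compound 3 cannot be read: the limit of > 2000 nM in this assay, at which 2 of the 3 values shown sit.

The compounds shown leave open whether an ethyl or a longer chain on the nitrogen would recover any of the number, or whether the phenyl must be present. They also leave open how a fluorine or a methoxy on that phenyl, or a pyridine ring in its place, would read.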